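Dimethoxyphenyl on the carbonyl in a chalcone-like series

A few compounds are considered here, and "the series" means these few. Any claim that something is new, unique, unknown or untested is made for them only; others in the source may bear on it.

Measured so far:
compound 1, `COc1ccc(-c2cc(/C=C/C(=O)c3ccc(OC)c(OC)c3)nc3cc(-c4ccccc4)nn23)cc1`: 7400 nM
compound 2, `COc1cc(-c2cc(/C=C/C(=O)c3ccccc3)nc3cc(-c4ccccc4)nn23)cc(OC)c1OC`: 18200 nM

In a functional assay on A549 cells (Homo sapiens) for antiproliferative activity, read by MTT assay, with a stated time of 24 h (a higher number here means a weaker inhibitor, a lower number a stronger inhibitor), compound 2 gives 18200 nM, the highest of the two numbers seen. Going by the values given here, its only neighbour, compound 1, gives 7400 nM, a gap that lies beyond the usual scatter, so compound 2 is the weaker of the two.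

Compound 3, `COc1ccc(C(=O)/C=C/c2cc(-c3cc(OC)c(OC)c(OC)c3)n3nc(-c4ccccc4)cc3n2)cc1OC`, has not yet been measured. It differs from compound 2 in one place: 3,4-dimethoxyphenyl in place of phenyl on a carbonyl carbon. Among the compounds with values here, compound 1 carries the same 3,4-dimethoxyphenyl on its carbonyl carbon, though it also differs from compound 2 elsewhere, so no clean step for this change alone is available. Given that compound 1 sits at 7400 nM, a moderate move toward a lower number is expected. The estimated step of a 2.0-fold lower number from compound 2 to compound 3 (0.31 log units; beyond the scatter) is expected to be modest, and compound 3 is expected at about 9000 nM, within 4000 nM to 20000 nM.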

Compound 3, half-maximal inhibitory concentration: 17800 nM
Estimate against measurement, compound 3: 2.0-fold (0.30 log units) below, and the stated range covers the measured number.
By their numbers in this assay, from the lowest: compound 1; then compounds 3 and 2 (each within the scatter of the next).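

In this assay, 3,4-dimethoxyphenyl in place of phenyl on the carbonyl carbon gives a 1.0-fold lower number from compound 2 to compound 3 (0.01 log units; within the scatter) and so leaves the number within the scatter, at least while 3,4,5-trimethoxyphenyl is present on the aromatic carbon. With 3,4-dimethoxyphenyl held on the carbonyl carbon, 3,4,5-trimethoxyphenyl in place of 4-methoxyphenyl on the aromatic carbon gives a 2.4-fold higher number from compound 1 to compound 3 (0.38 log units; beyond the scatter) and so, of the two single changes, only this one lies beyond the scatter. No supporting data bear on why either change behaves as it does.

On these data alone, it remains open whether the carbonyl change would read the same with 4-methoxyphenyl on the aromatic carbon. Also open, as far as these compounds go, is how a quite different group on the carbonyl carbon, such as an aminophenyl or a carboxyphenyl, would behave.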